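Removing one methyl from the 3,4-dimethylphenyl sulfonamide

A few compounds are considered here, and "the series" means these few. Any claim that something is new, unique, unknown or untested is made for them only; others in the source may bear on it.

The compounds share one core and differ only in the aryl group on the sulfonyl. In a functional assay on DLD-1 cells (Homo sapiens) for antiproliferative activity, read by CellTiter-Glo, with a stated time of 72 h (a higher number here means a weaker inhibitor, a lower number a stronger inhibitor), compound 3 `Cc1ccc(S(=O)(=O)N2CCC(N3CCC(C)CC3)CC2)cc1C` gives 24 nM, the highest of the two numbers available. Compound 2 `CC1CCN(C2CCN(S(=O)(=O)c3cccc(-c4ccccc4F)c3)CC2)CC1` gives 10 nM in this assay, the nearest value, and the gap between the two is beyond the scatter. Compound 1 `CC1CCN(C2CCN(S(=O)(=O)c3cccc(C(F)(F)F)c3)CC2)CC1` reaches only a limit in this assay, > 5000 nM, which is the limit of > 5000 nM in this assay, at which 1 of the 3 values shown sits, and not a number.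

The step to compound 4 `Cc1cccc(S(=O)(=O)N2CCC(N3CCC(C)CC3)CC2)c1` is hydrogen in place of methyl on an aromatic carbon, that is 3,4-dimethylphenyl to 3-methylphenyl. Within the data shown here, no measured step touches that methyl. Among the measured compounds shown here, the one measured step, an at least 500-fold lower number from compound 1 to compound 2 (2.69 log units; beyond the scatter), swaps a different group on the ring; it shows that the aryl pattern can move the number a long way, but it says nothing direct about removing a methyl. Compound 3 and compound 2 differ at more than one place, so their values show only that two distinct aryl patterns both give low numbers.

The expectation for compound 4 is a modest weakening, a 3.3-fold higher number from compound 3 to compound 4 (0.52 log units; beyond the scatter), with wide uncertainty. The estimate for compound 4 in this assay is 80 nM, between 20 nM and 600 nM.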

Compound 4, half-maximal inhibitory concentration: 25 nM
Compound 4: middle estimate off by 3.2-fold (0.51 log units), on the high side; low and high end bracket the measured number.
By their numbers in this assay, from the lowest: compound 2; then compounds 3 and 4 (each within the scatter of the next). At a limit, above all of these: compound 1.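

In this assay, the methyl that leaves, on an aromatic carbon ortho to a methyl group and para to a large group, makes no readable difference: a 1.0-fold higher number from compound 3 to compound 4 (0.02 log units; within the scatter), so 3,4-dimethylphenyl and 3-methylphenyl stand level in these notes. Among these compounds, compound 4 also gives the first direct comparisons of methyl with the two other groups on that aromatic carbon, with a 2.5-fold higher number from compound 2 to compound 4 (0.40 log units; beyond the scatter) and a far larger separation in an at least 200-fold lower number from compound 1 to compound 4 (2.30 log units; beyond the scatter), so a lone methyl keeps the number low, 2-fluorophenyl gives a modestly lower number, and only trifluoromethyl loses it. Compound 1 stands at a limit and not at a number, so the size of its step is a bound only: the limit of > 5000 nM in this assay, at which 1 of the 4 values shown sits.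

Whether the remaining methyl is itself needed stays open, since the compounds shown include no unsubstituted phenyl sulfonamide. Equally open, on these data alone, is how a chlorine, a methoxy group, an amine or a carboxylic acid on that aromatic carbon would compare with methyl and with trifluoromethyl in this assay.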